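The source may hold more compounds than are shown below. What is called first, only, known or untested is meant among the compounds shown, and "the series" means these compounds.

Series notes. The shared core carries a basic amine on a chain that ends in an oxygen on an aromatic ring. Compound 1 `CN(C)CCCCOc1ccc(C(=O)/C=C/c2ccccc2)cc1` gives 1.64 in a physicochemical assay for lipophilicity, using the shake flask method, measured as octanol-water partition, at pH 7.4 (on this read-out lower numbers stand for lower lipophilicity and higher numbers for higher lipophilicity), the lowest of the three numbers in hand. Compound 2 `CCN(CC)CCCCOc1ccc(C(=O)/C=C/c2ccccc2)cc1` gives 1.74 in this assay, and compound 3 `CCCCN(CCCC)CCCCOc1ccc(C(=O)/C=C/c2ccccc2)cc1` gives 2.09 in this assay. The step of a number 0.10 log units higher from compound 1 to compound 2 (within the scatter) and the step of a number 0.45 log units higher from compound 1 to compound 3 (beyond the scatter) both grow the amine substituents; the step of a number 0.35 log units higher from compound 2 to compound 3 (beyond the scatter) points the same way. Compound 4 `CN(C)CCCCCOc1ccc(C(=O)/C=C/c2ccccc2)cc1` is not yet measured. The change from compound 1 is (dimethylamino)methyl in place of dimethylamino on a saturated chain carbon, four bonds along the chain from an oxygen on an aromatic ring; it lengthens the chain by one carbon rather than the amine substituents. The measured steps each added carbon and each moved this assay upward by small amounts per carbon added, so a single extra carbon is expected to give a step upward that stays within the scatter. Compound 4 is therefore estimated at 1.75, with a range of 1.45 to 2.05, which corresponds to an expected step of a number 0.11 log units higher from compound 1 to compound 4 (within the scatter).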

Compound 4, partition coefficient: 1.73
Compound 4: middle estimate off by 0.02 log units, on the high side, and the stated range covers the measured number.
By their numbers in this assay, from the lowest: compounds 1, 4 and 2 (each within the scatter of the next); then compound 3.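

In this assay, the (dimethylamino)methyl change at this place alters the chain rather than the amine substituents, and its step stays within the scatter (a number 0.09 log units higher from compound 1 to compound 4 (within the scatter)). Compound 4 also cannot be told apart from compound 2 (a number 0.01 log units lower from compound 2 to compound 4 (within the scatter)), so the chain change and the diethylamino change are not separated here, whereas dibutylamino remains distinct from the chain change (a number 0.36 log units lower from compound 3 to compound 4 (beyond the scatter)). Nothing measured here accounts for these steps.

Still open, on these data alone, is whether a longer chain bearing dimethylamino would stay within the scatter of compound 1 or move beyond it. Also open, as far as these compounds go, is how a ring amine such as morpholine or piperidine in place of dimethylamino would compare on the same chain.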